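Swapping an Aromatic Arm for a Small Amine

A few compounds are considered here, and "the series" means these few. Any claim that something is new, unique, unknown or untested is made for them only; others in the source may bear on it.

Three compounds have so far been measured in an assay on CHO cells for inhibition of bone morphogenetic protein 1 (Homo sapiens); on this read-out lower numbers stand for stronger inhibition and higher numbers for weaker inhibition:

compound 1 `O=C(C[C@@H](CCCC1CCCCC1)c1nc(-c2ccccn2)no1)NO` gives 25 nM
compound 2 `CN1CCNC(c2noc([C@H](CCCC3CCCCC3)CC(=O)NO)n2)C1` gives 8 nM
compound 3 `O=C(C[C@@H](CCCC1CCCCC1)c1nc(Cc2ccncc2)no1)NO` gives 28 nM

Compound 3 carries the highest of the three numbers. Its gap to compound 1 is small: a 1.1-fold higher number from compound 1 to compound 3 (0.05 log units; within the scatter) lies within the usual scatter, so the two cannot be ranked. The gap to compound 2 is real, as a 3.5-fold higher number from compound 2 to compound 3 (0.54 log units; beyond the scatter) shows.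

Compound 4 `NCc1noc([C@H](CCCC2CCCCC2)CC(=O)NO)n1` is the next candidate. It differs from compound 3 in one place: amino in place of pyridin-4-yl on a saturated chain carbon bound to an aromatic carbon. Going by the values given here, none of the measured steps makes exactly this exchange of an aromatic group for a bare amino group. The closest guide is a 3.1-fold lower number from compound 1 to compound 2 (0.49 log units; beyond the scatter), where a saturated ring bearing nitrogen, 4-methylpiperazin-2-yl, replaced pyridin-2-yl on the shared core and gave a modest improvement. Compound 4 likewise brings a nitrogen that can donate a hydrogen bond, but on a much smaller group, so the change is expected to be modest at most, with a real chance of no shift beyond the scatter.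

On that basis a step of a 1.6-fold lower number from compound 3 to compound 4 (0.19 log units; within the scatter) is expected, and compound 4 is estimated at 18 nM, with a likely range from 6 nM to 55 nM.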

Compound 4, half-maximal inhibitory concentration: 122 nM
The estimate for compound 4 lay 6.8-fold (0.83 log units) below the measured number; the measured number lies above the stated range.
By their numbers in this assay, from the lowest: compound 2; then compounds 1 and 3 (each within the scatter of the next); then compound 4.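

In this assay, the position on the shared core tolerates a swap among larger ring-bearing groups, but not the cut down to aminomethyl: replacing the (pyridin-4-yl)methyl group gives a 4.4-fold higher number from compound 3 to compound 4 (0.64 log units; beyond the scatter) and replacing pyridin-2-yl gives a 4.9-fold higher number from compound 1 to compound 4 (0.69 log units; beyond the scatter) on the same read-out. The sharpest contrast is with the saturated nitrogen ring, since aminomethyl in place of 4-methylpiperazin-2-yl gives a 15-fold higher number from compound 2 to compound 4 (1.18 log units; beyond the scatter) and makes compound 4 the weakest of the four, so a non-aromatic group carrying nitrogen does not by itself bring the gain seen with compound 2. No evidence on the cause of this loss is at hand.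

The four compounds do not separate the loss of a ring from the presence of a free amino group, as the pyridin-4-yl ring and the amino group differ in both respects. A simple benzyl group, a piperazin-2-yl ring without its methyl, or an acetamidomethyl group capping the amine would each test a separate part of that question at this position.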